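The source may report more compounds than this note shows. Statements on the series, on what has been measured and on what is new or still open speak of the compounds shown alone.

Compound 1 `COc1ccc2[nH]c(-c3cccc(F)c3)cc(=O)c2c1O` serves as the reference point. In a functional assay on HCT-116 cells (Homo sapiens) for cytotoxicity, read by MTT assay, with a stated time of 48 h (on this read-out higher numbers stand for weaker inhibition and lower numbers for stronger inhibition), compound 1 gives 70 nM. Compound 2 `COc1ccc2[nH]c(-c3ccc(F)cc3)cc(=O)c2c1O` carries 4-fluorophenyl in place of 3-fluorophenyl on an aromatic carbon, and in this assay compound 2 gives 2400 nM, a step of a 34-fold higher number from compound 1 to compound 2 (1.54 log units; beyond the scatter). Compound 3 `COc1cc2c(=O)cc(-c3cccc(F)c3)[nH]c2cc1O` rests on a different core; how the two cores differ is not broken down here. In this assay compound 3 gives 1100 nM, a weaker inhibition than compound 1 shows. Going by the values given here, compound 4 `COc1cc2c(=O)cc(-c3ccc(F)cc3)[nH]c2cc1O` is not yet measured and carries 4-fluorophenyl in place of 3-fluorophenyl on an aromatic carbon, the same change at the same place as the one from compound 1 to compound 2. Because of the large step of a 34-fold higher number from compound 1 to compound 2 (1.54 log units; beyond the scatter), compound 4 is expected to show a step of an 11-fold higher number from compound 3 to compound 4 (1.04 log units; beyond the scatter), smaller than the earlier one since only one case on a different core supports it. Compound 4 is therefore estimated at 12000 nM, between 2500 nM and 60000 nM.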

Compound 4, half-maximal inhibitory concentration: > 100000 nM
Compound 4: only a limit was reported (the forecaster's own chance of this, stated with the estimate: 15%); at least 8.3-fold (0.92 log units) between middle value and limit.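

Putting 4-fluorophenyl in place of 3-fluorophenyl gives weaker inhibition on the core of compound 3, as it does on the core of compound 1, with a step of an at least 90-fold higher number from compound 3 to compound 4 (1.95 log units; beyond the scatter) in this assay, so the direction of the change carries over between these two cores. In this assay compound 4 gives > 100000 nM, which is a limit and not a number. Whether the change costs more on one core than on the other therefore stays unsettled, and a single pair of cores sets no rule for the series: the same change on two cores in this assay, a 34-fold higher number (1.54 log units; beyond the scatter) from compound 1 to compound 2 and an at least 90-fold higher number (1.95 log units; beyond the scatter) from compound 3 to compound 4; the limit leaves it open whether they differ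

The compounds shown leave open how an unsubstituted phenyl or a chlorophenyl would behave at this place. They also leave open whether the change would carry over to a core bearing an amine in place of the hydroxyl group.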